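Trifluoromethyl in place of trifluoromethoxy on compound 1

This account rests on a few compounds, and the source may have more. Where it says the series, first, only, none or still open, it means among the compounds named here.

Compound 1 `Cc1cc(NC(=O)Nc2ccccc2OC(F)(F)F)c2ccccc2n1`: > 25000 nM
Compound 2 `Cc1cc(NC(=O)Nc2ccc(Cl)c(Cl)c2)c2ccccc2n1`: 17000 nM
Compound 3 `Cc1cc(NC(=O)Nc2ccc(C(N)=O)cc2)c2ccccc2n1`: > 25000 nM

In an ADME assay on HepG2 cells (Homo sapiens) for cytotoxicity, with a stated time of 72 h (a higher number here means that more compound is needed for the effect, a lower number that less compound is needed), compound 1 gives > 25000 nM, which is a limit and not a number. Compound 1 shares with compound 3 (the limit of > 25000 nM in this assay, at which 2 of the 3 values shown sit). Among the measured compounds shown here, compound 2 gives 17000 nM, the only true number in the set.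

Compound 4 `Cc1cc(NC(=O)Nc2ccccc2C(F)(F)F)c2ccccc2n1` has trifluoromethyl in place of trifluoromethoxy on an aromatic carbon, ortho to a large group (trifluoromethyl in place of trifluoromethoxy on an aromatic carbon). For the measured compounds named here, no measured pair shows this exchange, so no step beyond the scatter is expected in this assay. That expectation rests on compound 1, whose > 25000 nM is a limit. The estimated a number no higher from compound 1 to compound 4 (the limit leaves the size open) is small. For compound 4 the estimate is 25000 nM, with an expected range from 13000 nM to 40000 nM.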

Compound 4, half-maximal effective concentration: > 25000 nM
Compound 4: no number, only a limit; the forecaster's own chance of this, stated with the estimate: 70%; the middle value lies on the limit itself.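

In this assay, among the compounds shown here, compound 1 and compound 4 each give only a limit, and no step between them can be read. The compounds shown leave open whether exchanging trifluoromethoxy for trifluoromethyl changes the value at all.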